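This account rests on a few compounds, and the source may have more. Where it says the series, first, only, none or still open, it means among the compounds named here.

Within the data shown here, compound 2 `COc1cc(-c2nc(-c3ccccc3)[nH]c2-c2ccnc(NCCCNS(=O)(=O)c3cccc4ccccc34)n2)ccc1Cl` gives 13500 nM in a functional assay on LOX IMVI cells (Homo sapiens) for cytotoxicity, read by MTT assay, with a stated time of 24 h (on this read-out higher numbers stand for weaker inhibition and lower numbers for stronger inhibition), the higher of the two numbers so far, while compound 1 `COc1cc(-c2nc(-c3ccccc3)[nH]c2-c2ccnc(NCCCNS(=O)(=O)c3ccc(C(F)(F)F)cc3)n2)ccc1Cl` gives 1780 nM in this assay, the two being separated by a 7.6-fold higher number from compound 1 to compound 2 (0.88 log units; beyond the scatter). Compound 3 `O=S(=O)(NCCCNc1nccc(-c2[nH]c(-c3ccccc3)nc2-c2ccc(Cl)c(O)c2)n1)c1cccc2ccccc12` has not yet been measured in this assay. It differs from compound 2 by hydrogen in place of methyl on an oxygen on an aromatic ring. Among the measured compounds shown here, the single measured step, a 7.6-fold higher number from compound 1 to compound 2 (0.88 log units; beyond the scatter), concerns a change on the sulfonyl sulfur and says nothing about the oxygen on the aromatic ring, so no measured step bears on the change from compound 2 to compound 3. For the measured compounds named here, with no comparable step among the measured compounds, the expectation for compound 3 in this assay is a step of about a 1.1-fold lower number from compound 2 to compound 3 (0.05 log units; within the scatter), that is, none beyond the scatter. Going by these compounds, compound 3 is therefore estimated at 12000 nM, with a range from 4000 nM to 40000 nM, the width reflecting that the change is untested here.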

Compound 3, half-maximal inhibitory concentration: 7720 nM
The estimate for compound 3 lay 1.6-fold (0.19 log units) above the measured number; measured number inside the range.
By their numbers in this assay, from the lowest: compound 1; then compounds 3 and 2 (each within the scatter of the next).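

Among these compounds, compound 3 gives the first reading at this position: going from methoxy to hydroxy on the 4-chloro-3-methoxyphenyl ring, with the naphthalen-1-yl group on the sulfonyl sulfur kept, gives a 1.7-fold lower number from compound 2 to compound 3 (0.24 log units; within the scatter) in this assay. Losing this one methyl carbon therefore leaves the number within the scatter, whereas the change on the sulfonyl sulfur, a 7.6-fold higher number from compound 1 to compound 2 (0.88 log units; beyond the scatter), lies beyond it. Nothing available here bears on why this oxygen tolerates the exchange in this assay.

Going by these compounds, it remains open whether the same exchange would also stay within the scatter with 4-(trifluoromethyl)phenyl on the sulfonyl sulfur. On these data alone, it is equally open how a larger group on this oxygen, such as an ethyl or a longer chain ending in an amine, would read here.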